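Replacing the sulfamoyl group of compound 2

This account rests on a few compounds, and the source may have more. Where it says the series, first, only, none or still open, it means among the compounds named here.

Measured compounds:
compound 1 `CC#C[C@H]1CN(S(=O)(=O)c2ccc(N)nc2)CCN1c1ccc(S(=O)(=O)NC)cn1` gives 381 nM in an assay on cells (Hepatocyte) for inhibition of glucokinase regulatory protein (Mus musculus), with stated times of 20 min and 40 min; a lower number here means that less compound is needed, a higher number that more compound is needed for the effect
compound 2 `CC#C[C@H]1CN(S(=O)(=O)c2ccc(N)nc2)CCN1c1ccc(S(N)(=O)=O)cc1` gives 37 nM in this assay

Of the two numbers measured in this assay, compound 2 stands lowest. Its nearest neighbour is compound 1, and the gap between the two lies beyond the usual scatter of this kind of measurement, so compound 2 needs clearly less material for the same effect than compound 1. Beyond this pair nothing else has been measured, and no step between compounds that differ in a single place is available as a guide.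

Compound 3 `CC#CCC(O)(c1ccc(N2CCN(S(=O)(=O)c3ccc(N)nc3)C[C@@H]2C#CC)cc1)C(F)(F)F` departs from compound 2 in one place: a group of 10 heavy atoms (6 carbon, 1 oxygen, 3 fluorine; no ring) in place of a group of 4 heavy atoms (1 nitrogen, 2 oxygen, 1 sulfur; no ring), on an aromatic carbon. For the measured compounds named here, because no comparable step is known, the size and direction of the change in this assay cannot be read from the data; a step of roughly the scatter, in either direction, is expected, with the new group neither clearly helping nor clearly hurting. The expected step from compound 2 to compound 3 is a 1.2-fold lower number from compound 2 to compound 3 (0.09 log units; within the scatter). For compound 3 the estimate in this assay is 30 nM, with a range from 8 nM to 120 nM.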

Compound 3, half-maximal effective concentration: 137 nM
The estimate for compound 3 lay 4.6-fold (0.66 log units) below the measured number; measured number outside the range, above it.
By their numbers in this assay, from the lowest: compound 2; then compound 3; then compound 1.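

In this assay the step is a 3.7-fold higher number from compound 2 to compound 3 (0.57 log units; beyond the scatter) and it is modest, which shows that this aromatic carbon, para to a large group, is sensitive to the group placed on it. The sulfamoyl group is thus not freely exchangeable here, even for a group that, like it, has 1 hydrogen-bond donor and no net charge, yet the larger group without a ring still leaves compound 3 with 137 nM as a measurable value. Nothing at hand accounts for the shift.

The new group differs from sulfamoyl in size, atoms and bond types all at once, so these compounds do not reveal which part of it, whether the hydroxyl, the trifluoromethyl or the chain with its triple bond, goes with the higher number. Also open, from the compounds shown here alone, is how simpler groups at this place, such as a lone hydroxyl, a trifluoromethyl, a carboxylic acid or an amine, would compare with sulfamoyl on the same core.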